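Nitro position shift on the ethoxy analogue

The source may hold more compounds than are shown below. What is called first, only, known or untested is meant among the compounds shown, and "the series" means these compounds.

Compound 1 `CCOc1c(Br)cc(/C=C2\CCC/C(=C\c3cccc([N+](=O)[O-])c3)C2=O)cc1OC` gives 19.3 ug/mL in a functional assay on MDA-MB-231 cells (Homo sapiens) for cytotoxicity, read by MTT assay (a lower number here means a stronger inhibitor, a higher number a weaker inhibitor), the highest of the three numbers in hand. Compound 2 `CCCOc1c(Br)cc(/C=C2\CCC/C(=C\c3cccc([N+](=O)[O-])c3)C2=O)cc1OC` gives 2.99 ug/mL and compound 3 `CCCCOc1c(Br)cc(/C=C2\CCC/C(=C\c3cccc([N+](=O)[O-])c3)C2=O)cc1OC` gives 5.53 ug/mL in this assay. The measured steps all concern the alkoxy chain: a 6.5-fold lower number from compound 1 to compound 2 (0.81 log units; beyond the scatter), a 3.5-fold lower number from compound 1 to compound 3 (0.54 log units; beyond the scatter), and a 1.8-fold higher number from compound 2 to compound 3 (0.27 log units; within the scatter). Compound 4 `CCOc1c(Br)cc(/C=C2\CCC/C(=C\c3ccc([N+](=O)[O-])cc3)C2=O)cc1OC` differs from compound 1 in another part of the molecule: 4-nitrophenyl in place of 3-nitrophenyl on a double-bonded chain carbon bound to a double-bonded ring carbon. Among the measured compounds shown here, none of the measured steps touches the nitrophenyl ring, so there is no measured step that bears on this change, and the alkoxy steps say nothing about it. For the measured compounds named here, with no bearing step, the expectation for compound 4 is no step beyond the scatter from compound 1 in this assay, giving a 1.0-fold lower number from compound 1 to compound 4 (0.01 log units; within the scatter) as the estimate. Compound 4 is therefore expected to give about 19 ug/mL in this assay, within a range of 7 ug/mL to 50 ug/mL.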

Compound 4, half-maximal inhibitory concentration: 34.7 ug/mL
Beside the measured number, compound 4's estimate is 1.8-fold (0.26 log units) below it; the measured number falls inside the stated range.
By their numbers in this assay, from the lowest: compounds 2 and 3 (each within the scatter of the next); then compounds 1 and 4 (each within the scatter of the next).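

The nitrophenyl ring now has a measured step, and 4-nitrophenyl in place of 3-nitrophenyl gives a 1.8-fold higher number from compound 1 to compound 4 (0.25 log units; within the scatter) in this assay, a change that stays within the scatter. Moving the nitro group on this ring therefore has no resolved effect on the ethoxy analogue, whereas the alkoxy chain change gives a 6.5-fold lower number from compound 1 to compound 2 (0.81 log units; beyond the scatter) and lies beyond the scatter. Nothing available explains the outcome at this position.

Going by these compounds, whether the same nitro shift also stays within the scatter on the propoxy chain of compound 2 or the butoxy chain of compound 3 remains open, as the shift is read only on the ethoxy analogue. Also open, on these data alone, is how an amine, a carboxylic acid or a nitrile in place of the nitro group on this ring would read.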